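Chain extension steps on a shared bicyclic core

The source may hold more compounds than are shown below. What is called first, only, known or untested is meant among the compounds shown, and "the series" means these compounds.

Compound 1 `CCCCCNc1nc(SCC)nc2ncccc12` is the reference point; in a functional assay on HT-29 cells (Homo sapiens) for cytotoxicity, read by neutral red uptake, with a stated time of 72 h (on this read-out higher numbers stand for weaker inhibition and lower numbers for stronger inhibition), compound 1 gives 5100 nM. Compound 2 `CCCCCCNc1nc(SCC)nc2ncccc12` differs from it by methyl in place of hydrogen on a saturated chain carbon, five bonds along the chain from a nitrogen on an aromatic ring and in this assay compound 2 gives 22500 nM, so that a 4.4-fold higher number from compound 1 to compound 2 (0.64 log units; beyond the scatter). Compound 3 `CCCCCCNc1nc(SCCCC)nc2ncccc12` in turn differs from compound 2 by ethyl in place of hydrogen on a saturated chain carbon, two bonds along the chain from a sulfur; in this assay compound 3 gives 2800 nM, which means an 8.0-fold lower number from compound 2 to compound 3 (0.91 log units; beyond the scatter). Compound 3 and compound 1 differ in more than one place, and the difference between the two cores is not broken down here; their two values lie within the usual scatter of each other.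

Compound 4 `CCCCCCNc1nc(SCCCCC)nc2ncccc12` has not been measured. It differs from compound 3 by methyl in place of hydrogen on a saturated chain carbon, four bonds along the chain from a sulfur. This is the same kind of change as that from compound 1 to compound 2, but not the same change: there the methyl enters five bonds along the chain from a nitrogen on an aromatic ring, here four bonds along the chain from a sulfur. The earlier step, a 4.4-fold higher number from compound 1 to compound 2 (0.64 log units; beyond the scatter), went toward higher numbers, whereas growing the chain on the sulfur side, an 8.0-fold lower number from compound 2 to compound 3 (0.91 log units; beyond the scatter), went toward lower numbers. The two steps pull in opposite directions. A small step is therefore expected for compound 4, a 1.4-fold lower number from compound 3 to compound 4 (0.15 log units; within the scatter). This rests on compound 3 and compound 2, because an 8.0-fold lower number from compound 2 to compound 3 (0.91 log units; beyond the scatter) favours lower numbers on this side of the core, tempered by compound 1 and compound 2, because a 4.4-fold higher number from compound 1 to compound 2 (0.64 log units; beyond the scatter) shows that a methyl added to a chain can also raise the number. The estimate for compound 4 in this assay is 2000 nM, with a range from 600 nM to 7000 nM.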

Compound 4, half-maximal inhibitory concentration: 18400 nM
For compound 4 the middle estimate is 9.2-fold (0.96 log units) below the measured one; measured number outside the range, above it.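

In this assay the methyl step on the second core gives a 6.6-fold higher number from compound 3 to compound 4 (0.82 log units; beyond the scatter), and it matches the earlier step in direction and size: the same change on two cores in this assay, a 4.4-fold higher number (0.64 log units; beyond the scatter) from compound 1 to compound 2 and a 6.6-fold higher number (0.82 log units; beyond the scatter) from compound 3 to compound 4, 1.5-fold (0.17 log units) apart, within the scatter of two such steps. Across these two pairs the change carries from one core to the other, even though the methyl enters five bonds along the chain from a nitrogen on an aromatic ring in one pair and four bonds along the chain from a sulfur in the other. Going by these compounds alone, this rests on only two pairs in a single assay, so it does not show that the step holds on other cores or explain why the number rises, and the sulfur chain does not behave in a simple way: ethyl in place of hydrogen gives an 8.0-fold lower number from compound 2 to compound 3 (0.91 log units; beyond the scatter), whereas propyl in the same place gives a 1.2-fold lower number from compound 2 to compound 4 (0.09 log units; within the scatter), a difference within the scatter.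

The compounds shown leave open whether the number keeps rising with a longer chain on the sulfur, or whether compound 3 marks a narrow low point in that chain series. They also leave open how the number responds when a chain ends in an amine or a carboxylic acid rather than a methyl.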